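This account rests on a few compounds, and the source may have more. Where it says the series, first, only, none or still open, it means among the compounds named here.

In a functional assay on DU-145 cells (Homo sapiens) for inhibition (a higher number here means a weaker inhibitor, a lower number a stronger inhibitor), compound 1 `CCOc1ccc(Br)cc1-c1cc(Nc2ccc(C(=O)NO)cc2)nc(N)n1` is reported only as a limit, > 1000 nM. Going by the values given here, compound 2 `Cc1ccc(Br)cc1-c1cc(Nc2ccc(Cl)cc2)nc(N)n1` gives 100 nM, so it holds the only actual number so far. The next compound, compound 3 `CCOc1ccc(Br)cc1-c1cc(Nc2ccc(Cl)cc2)nc(N)n1`, keeps the core of compound 2 and has ethoxy in place of methyl on an aromatic carbon, (ethoxy in place of methyl on an aromatic carbon). That carbon is ortho to a large group and para to a bromo group. Among the compounds with values here, no measured pair isolates this change, so the expectation is uncertain: a modest step toward weaker inhibition in this assay, possibly not much beyond the scatter. The expected change is a 1.8-fold higher number from compound 2 to compound 3 (0.26 log units; within the scatter). For compound 3 the estimated value is 180 nM, with an expected range from 50 nM to 600 nM.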

Compound 3, half-maximal inhibitory concentration: 80 nM
Beside the measured number, compound 3's estimate is 2.3-fold (0.35 log units) above it, and the stated range covers the measured number.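

In this assay, ethoxy in place of methyl on the aromatic carbon ortho to a large group and para to a bromo group gives a 1.3-fold lower number from compound 2 to compound 3 (0.10 log units; within the scatter) and so leaves the read-out unmoved, which shows that this position takes ethoxy as well as methyl. Going by these compounds alone, with ethoxy held constant, chloro in place of hydroxycarbamoyl gives an at least 12-fold lower number from compound 1 to compound 3 (1.09 log units; beyond the scatter) as a large step, the first comparison that isolates this site. Going by these compounds, compound 1 holds only a limit, so the full size of that step stays unknown: the limit of > 1000 nM in this assay, at which 1 of the 3 values shown sits.

The compounds shown leave open whether a longer chain or an amine at the ethoxy position would still match methyl and ethoxy. They also leave open how a carboxylic acid would read in place of chloro, and whether the ethoxy result holds with hydroxycarbamoyl present.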